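The compounds below may be only part of what the source reports. "The series", "measured", "known", "first", "only" and "open" are said of these compounds alone.

Going by the values given here, in a functional assay on MGC-803 cells (Homo sapiens) for inhibition, read by MTT assay, with a stated time of 48 h (a higher number here means a weaker inhibitor, a lower number a stronger inhibitor), compound 2 (`C/C=C/C(=O)N(Cc1ccc(OC)cc1)c1cc(OC)c(OC)c(OC)c1`) gives 450 nM and stands lowest of the two numbers so far, while compound 1 (`C/C=C/C(=O)N(Cc1ccc(OC)c(OC)c1)c1cc(OC)c(OC)c(OC)c1`) gives 20100 nM as the other. Compound 3 (`C/C=C/C(=O)N(Cc1ccc(OC)c(Cl)c1)c1cc(OC)c(OC)c(OC)c1`) differs from compound 2 in one place (chloro in place of hydrogen on an aromatic carbon), turning 4-methoxyphenyl into 3-chloro-4-methoxyphenyl. Among the compounds with values here, compound 1 holds a methoxy group where compound 3 holds chloro, so the one measured step that bears on this (a 45-fold lower number from compound 1 to compound 2 (1.65 log units; beyond the scatter)), large and beyond the scatter, points to an expected higher number for compound 3, though chloro is a different group and the size stays uncertain. The expected change is a weakening (a 5.6-fold higher number from compound 2 to compound 3 (0.74 log units; beyond the scatter)). For compound 3 the estimated value is 2500 nM within an estimated range (450 nM to 15000 nM).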

Compound 3, half-maximal inhibitory concentration: 7100 nM
Beside the measured number, compound 3's estimate is 2.8-fold (0.45 log units) below it, and the stated range covers the measured number.
By their numbers in this assay, from the lowest: compound 2; then compound 3; then compound 1.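

Putting chloro on this ring carbon costs a great deal of activity (a 16-fold higher number from compound 2 to compound 3 (1.20 log units; beyond the scatter)), so the loss seen with an added methoxy group is not unique to methoxy. Chloro is the milder of the two groups at this place (a 2.8-fold lower number from compound 1 to compound 3 (0.45 log units; beyond the scatter)), although compound 3 remains well short of compound 2, which has only hydrogen there. Nothing available here explains why either group weakens the compound.

Still open, on these data alone, is whether any group at this place can match hydrogen. Fluoro, a hydroxyl group or an amine would test whether the loss extends beyond chloro and methoxy.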